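The compounds below may be only part of what the source reports. "The series", "measured", "known", "first", "only" and "open" are said of these compounds alone.

Compound 1 `N/C(=N\NC(=S)N1CCCCC1)c1ccccn1` was tested in a functional assay on HeLa cells (Homo sapiens) for cytotoxicity, read by MTT assay, with a stated time of 72 h, tested at 3 uM (a lower number here means less inhibition of growth, a higher number more inhibition of growth at the concentration tested), and gave 49.2%. Compound 2 `N/C(=N\NC(=S)N1CCCC1)c1ccccn1` gave 38.5% in this assay. The two differ by pyrrolidin-1-yl in place of piperidin-1-yl on a thiocarbonyl carbon, and that change made a number 10.7 percentage points lower from compound 1 to compound 2 (beyond the scatter). Compound 3 `Cc1ccnc(/C(N)=N/NC(=S)N2CCCCC2)c1` differs from compound 1 by methyl in place of hydrogen on an aromatic carbon. In this assay compound 3 gave 23.9%, which is a number 25.3 percentage points lower from compound 1 to compound 3 (beyond the scatter). Compound 4 `Cc1ccnc(/C(N)=N/NC(=S)N2CCCC2)c1` has not yet been tested. It carries the same change as the pair compound 1 and compound 2, namely (pyrrolidin-1-yl in place of piperidin-1-yl on a thiocarbonyl carbon), at a place described in identical words. That change earlier made a number 10.7 percentage points lower from compound 1 to compound 2 (beyond the scatter). For compound 4 a step of a number 10.9 percentage points lower from compound 3 to compound 4 (beyond the scatter) is therefore expected, of similar size to the earlier one. On this basis compound 4 is expected to give 13% in this assay, most likely between 0% and 28%, an expectation that rests on a single earlier example.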

Compound 4, percent growth inhibition at one concentration: 52.1%
The estimate for compound 4 lay 39.1 percentage points below the measured number, and the stated range ends below it.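

Replacing piperidin-1-yl with pyrrolidin-1-yl gave a number 28.2 percentage points higher from compound 3 to compound 4 (beyond the scatter) in this assay, so the change did not behave as it had on the core of compound 1: the same change on two cores in this assay, a number 10.7 percentage points lower (beyond the scatter) from compound 1 to compound 2 and a number 28.2 percentage points higher (beyond the scatter) from compound 3 to compound 4, 38.9 percentage points apart, beyond the scatter of two such steps

Adding the methyl group gave a number 13.6 percentage points higher from compound 2 to compound 4 (beyond the scatter), and this too differs from its earlier step: the same change on two cores in this assay, a number 25.3 percentage points lower (beyond the scatter) from compound 1 to compound 3 and a number 13.6 percentage points higher (beyond the scatter) from compound 2 to compound 4, 38.9 percentage points apart, beyond the scatter of two such steps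

Among these four compounds, the effect of each change therefore depends on the other, so a step seen on one core cannot simply be carried to another, but the numbers do not show why this happens or whether it extends beyond these compounds.

The compounds shown leave open whether other rings on the thiocarbonyl carbon, such as morpholin-4-yl or azepan-1-yl, would follow the same pattern. They also leave open what an ethyl group or a chlorine atom would do in place of the methyl.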